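Another Ring-Bearing Group at the Same Aromatic Carbon

A few compounds are considered here, and "the series" means these few. Any claim that something is new, unique, unknown or untested is made for them only; others in the source may bear on it.

Of the compounds shown here, two sharing one core have been measured; a third awaits its number.

Compound 1, `Cc1cc(Cl)cc(-c2ccnc3cc(CN4C(=O)CCC4=O)sc23)c1O[C@H]1C[C@H](N)C1`, gives 3.4 nM in an assay on isolated protein for inhibition of ubiquitin carboxyl-terminal hydrolase 7 (Homo sapiens), read by fluorescence, with stated times of 30 min and 1 h; on this read-out lower numbers stand for stronger inhibition and higher numbers for weaker inhibition.
Compound 2, `Cc1cc(Cl)cc(-c2ccnc3cc(CN4C(=O)CCC4=O)sc23)c1CN1CCNC[C@@H]1C`, gives 6.6 nM in this assay.

Among the measured compounds shown here, on the two numbers so far, compound 2 is separated from its only neighbour by a step within the scatter: a 1.9-fold higher number from compound 1 to compound 2 (0.29 log units; within the scatter). Compound 3, `Cc1cc(Cl)cc(-c2ccnc3cc(CN4C(=O)CCC4=O)sc23)c1O[C@H]1CCCNC1`, differs from compound 2 in that ((piperidin-3-yl)oxy in place of (2-methylpiperazin-1-yl)methyl on an aromatic carbon). For the measured compounds named here, the one measured step that bears on this change took place at the same aromatic carbon, where one ring-bearing group replaced another: a 1.9-fold higher number from compound 1 to compound 2 (0.29 log units; within the scatter), a movement within the scatter. Compound 3 carries a third such group at that carbon, and on this evidence the expected step in this assay is a 1.3-fold lower number from compound 2 to compound 3 (0.12 log units; within the scatter), none beyond the scatter, direction undecided. Compound 3 is therefore estimated at 5 nM, within a range of 2 nM to 12 nM.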

Compound 3, half-maximal inhibitory concentration: 4.6 nM
For compound 3 the middle estimate is 1.1-fold (0.04 log units) above the measured one, and the stated range covers the measured number.
By their numbers in this assay, from the lowest: compounds 1, 3 and 2 (each within the scatter of the next).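

In this assay, exchanging the (2-methylpiperazin-1-yl)methyl group for a (piperidin-3-yl)oxy group on this aromatic carbon gives a 1.4-fold lower number from compound 2 to compound 3 (0.16 log units; within the scatter) and so adds a third ring-bearing group whose step stays within the scatter. Among the compounds shown here, the new compound also allows the first comparison in which the oxygen on the aromatic ring is kept and only the ring on it changes: piperidin-3-yl in place of 3-aminocyclobutyl gives a 1.4-fold higher number from compound 1 to compound 3 (0.13 log units; within the scatter) and this step also stays within the scatter. Nothing available here explains why these groups give such close numbers.

Going by these compounds, all three groups carry an amine nitrogen, so what a methoxy group, or a group ending in a carboxylic acid, would do at this carbon stays open. Also open, on these data alone, is how the opposite configuration at the defined stereocentre of the piperidin-3-yl group would read.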